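This account rests on a few compounds, and the source may have more. Where it says the series, first, only, none or still open, it means among the compounds named here.

Measured compounds:
- compound 1, `CNC(=O)C[C@@H]1C[C@@H](c2ccc(Cl)c(Cl)c2)[C@H](NC(=O)c2cc(-c3c(Cl)cnn3C)c(Cl)o2)CN1`: 1130 nM
- compound 2, `Cn1ncc(Cl)c1-c1cc(C(=O)N[C@@H]2CN[C@H](CC(N)=O)C[C@H]2c2ccc(Cl)c(Cl)c2)oc1Cl`: 1000 nM
- compound 3, `C=CC[C@@H]1C[C@@H](c2ccc(Cl)c(Cl)c2)[C@H](NC(=O)c2cc(-c3c(Cl)cnn3C)c(Cl)o2)CN1`: 990 nM

These three compounds share one core and were each tested in a functional assay on OVCAR-8 cells (Homo sapiens) for antiproliferative activity; on this read-out higher numbers stand for weaker inhibition and lower numbers for stronger inhibition. The number for compound 1 is the highest of the three, but its gaps to the others are small: a 1.1-fold lower number from compound 1 to compound 2 (0.05 log units; within the scatter) and a 1.1-fold lower number from compound 1 to compound 3 (0.06 log units; within the scatter), both within the scatter, as is a 1.0-fold lower number from compound 2 to compound 3 (0.00 log units; within the scatter). The part of the molecule that varies among them is the chain attached to the saturated ring carbon, and so far every change there has left the read-out essentially unchanged.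

Compound 4, `Cn1ncc(Cl)c1-c1cc(C(=O)N[C@@H]2CN[C@H](CCN3CCCC3)C[C@H]2c2ccc(Cl)c(Cl)c2)oc1Cl`, has not yet been measured. It differs from compound 1 at that same place: (pyrrolidin-1-yl)methyl in place of methylcarbamoyl on a saturated chain carbon bound to a saturated ring carbon. The step that bears most directly on it is the replacement of methylcarbamoyl by vinyl, a 1.1-fold lower number from compound 1 to compound 3 (0.06 log units; within the scatter), where a hydrogen-bond donor was removed and the number did not move beyond the scatter. The change to compound 4 also removes that donor, though it brings in a larger ring-bearing group. The expected step is therefore a 1.3-fold lower number from compound 1 to compound 4 (0.10 log units; within the scatter), meaning no change beyond the scatter. Compound 4 is thus estimated at 900 nM, within a range of 350 nM to 2500 nM.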

Compound 4, half-maximal inhibitory concentration: 1840 nM
For compound 4 the middle estimate is 2.0-fold (0.31 log units) below the measured one; low and high end bracket the measured number.
By their numbers in this assay, from the lowest: compounds 3, 2, 1 and 4 (each within the scatter of the next).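

In this assay, among the compounds shown here, the (pyrrolidin-1-yl)methyl group of compound 4 is the only group of the four at this place that carries a ring, yet the read-out stays within the scatter of all three earlier compounds: there is a 1.6-fold higher number from compound 1 to compound 4 (0.21 log units; within the scatter) and a 1.8-fold higher number from compound 2 to compound 4 (0.26 log units; within the scatter) and a 1.9-fold higher number from compound 3 to compound 4 (0.27 log units; within the scatter) in this comparison. The earlier compounds shown here showed this only for small open chains, whereas this result extends it to a group of 6 heavy atoms with a five-membered non-aromatic ring, in place of the 4 heavy atoms of methylcarbamoyl, on a saturated chain carbon bound to a saturated ring carbon. Nothing presented here accounts for this flat response.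

Going by these compounds, whether a carboxylic acid, a dimethylamino group, a morpholine ring or a longer chain at this place would shift the number beyond the scatter remains open. On these data alone, all four compounds also share the rest of the core, so it is equally open whether this place would respond in the same way if another part of the molecule were changed.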